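The compounds below may be only part of what the source reports. "The series", "measured", "known", "first", "only" and "open" are said of these compounds alone.

The study follows a small set of compounds in a functional assay on HCT-116 cells (Homo sapiens) for cytotoxicity, read by MTT assay, with a stated time of 72 h; a lower number here means a stronger inhibitor, a higher number a weaker inhibitor. Compound 1 `COc1ccc(CNC(=O)c2nc(Br)c3cccnc3c2N[C@H]2CC[C@H](N)CC2)cc1` gives 3000 nM in this assay. Compound 3 `CS(=O)(=O)NCCCCCCN(c1nc(C(=O)NCc2ccc(F)cc2)c(O)c2ncccc12)S(C)(=O)=O` gives 3000 nM in this assay, level with compound 1 at the digits shown, so the two lie within the usual scatter of each other and no order between them can be read. Compound 2 `O=C(NCc1ccc(F)cc1)c1nc(Br)c2cccnc2c1N1CCNCC1` sits at the limit of > 10000 nM in this assay, at which 1 of the 3 values shown sits, which is a limit of this assay and not a number, and compound 2 is recorded there as > 10000 nM.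

Compound 4 `N[C@H]1CC[C@H](Nc2c(C(=O)NCc3ccccc3)nc(Br)c3cccnc23)CC1` has not yet been measured. It differs from compound 1 in one place: hydrogen in place of methoxy on an aromatic carbon, the methoxy leaving and hydrogen entering on an aromatic carbon of a six-membered aromatic ring of carbon only, para to a large group. Among the measured compounds shown here, no measured pair in this set makes the same change, so the size of the step has to be estimated from the change alone. The step expected in this assay is no change at the digits printed from compound 1 to compound 4 (within the scatter), small enough to stay within the usual scatter. Compound 4 is therefore expected to give about 3000 nM in this assay, with a likely range from 1500 nM to 7000 nM.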

Compound 4, half-maximal inhibitory concentration: 7000 nM
Compound 4: middle estimate off by 2.3-fold (0.37 log units), on the low side; the range from low to high includes it.
By their numbers in this assay, from the lowest: compounds 1 and 3 (each within the scatter of the next); then compound 4. At a limit, above all of these: compound 2.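

Among the compounds shown here, until this result, no pair in this assay differed in a single place, and this is the first step that can be read at one position: going from 4-methoxybenzyl to benzyl gives a 2.3-fold higher number from compound 1 to compound 4 (0.37 log units; beyond the scatter) and is modest but beyond the scatter. It shows that the substituent on this aromatic carbon, para to a large group, is not neutral in this series, as the pair with the methoxy has the lower number. Nothing in the data shown accounts for this step.

On these data alone, it remains open whether an ethoxy, a hydroxyl or a chlorine on the same carbon would stay with compound 1 or move as hydrogen does. The 4-fluorobenzyl group of compounds 2 and 3 cannot settle this, as those compounds differ from compound 1 in more than one place.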